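This account rests on a few compounds, and the source may have more. Where it says the series, first, only, none or still open, it means among the compounds named here.

Two compounds in the series have numbers in a functional assay on cells for antagonist activity at Orexin receptor type 2 (Homo sapiens), read by fluorescence and calcium flux, with a stated time of 30 min (a higher number here means a weaker inhibitor, a lower number a stronger inhibitor), so far. Compound 1 `Cc1ccc(-n2nccn2)c(C(=O)N(C)[C@@H](C)Cn2cc(-c3ccc(F)cn3)cn2)c1` gives 21.2 nM. Compound 2 `CCN(C(=O)c1nc(C)ccc1-n1nccn1)[C@@H](C)Cn1nnc(-c2ccc(F)cc2)n1` gives 119 nM, the higher of the two numbers, and the gap to compound 1 lies beyond the scatter. Compound 3 `CCN(C(=O)c1nc(C)ccc1-c1ncccn1)[C@@H](C)Cn1nnc(-c2ccc(F)cc2)n1` has not yet been measured; it differs from compound 2 by pyrimidin-2-yl in place of 2H-1,2,3-triazol-2-yl on an aromatic carbon. Among the compounds with values here, no measured pair shows the effect of this change, so in this assay the expected step is a 1.3-fold higher number from compound 2 to compound 3 (0.10 log units; within the scatter), amounting to none beyond the scatter. Compound 3 is accordingly estimated at 150 nM, with a range from 50 nM to 500 nM.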

Compound 3, half-maximal inhibitory concentration: 1310 nM
Compound 3: the middle estimate sits 8.7-fold (0.94 log units) below what was measured, outside the stated range (above it).
By their numbers in this assay, from the lowest: compound 1; then compound 2; then compound 3.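

In this assay, within the data shown here, pyrimidin-2-yl in place of 2H-1,2,3-triazol-2-yl, on the aromatic carbon ortho to a large group, gives an 11-fold higher number from compound 2 to compound 3 (1.04 log units; beyond the scatter) as the first single-place step. At this position the two aromatic rings are therefore not interchangeable. Nothing available gives a cause for this step.

The compounds shown leave open whether pyrazol-1-yl or phenyl at this carbon stays closer to compound 2. On these data alone, whether the same change gives a similar step on the core of compound 1 also remains open.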